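A few compounds are considered here, and "the series" means these few. Any claim that something is new, unique, unknown or untested is made for them only; others in the source may bear on it.

Of the compounds shown here, three have been measured in a functional assay on HT-29 cells (Homo sapiens) for antiproliferative activity, with a stated time of 48 h; a lower number here means a stronger inhibitor, a higher number a weaker inhibitor. Compound 1 `O=C(NCCCCl)Nc1ccc(I)cc1` gives 90000 nM, compound 2 `CC(C)(C)c1ccc(NC(=O)NCCCCl)cc1` gives 28000 nM, and compound 3 `CC(C)(C)c1ccc(CNC(=O)CCCl)cc1` gives 87000 nM. Going by the values given here, compound 2 therefore stands lowest of the three, and the only one-place step among them, a 3.2-fold lower number from compound 1 to compound 2 (0.51 log units; beyond the scatter), is modest but beyond the scatter. Compound 4 `CC(C)(C)c1ccc(NC(=O)CCCCl)cc1` differs from compound 2 in one place: 3-chloropropyl in place of (3-chloropropyl)amino on a carbonyl carbon. Among the compounds with values here, no measured step reproduces this change; compound 3 also carries a 3-chloropropyl on its carbonyl carbon, but it differs from compound 2 in more than one place, so its higher number is only a loose hint. For compound 4 a small weakening is expected, a 1.8-fold higher number from compound 2 to compound 4 (0.25 log units; within the scatter), with the number in this assay estimated at 50000 nM and a range from 15000 nM to 150000 nM.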

Compound 4, half-maximal inhibitory concentration: > 100000 nM
Compound 4: no number, only a limit (the forecaster's own chance of this, stated with the estimate: 15%); at least 2.0-fold (0.30 log units) between middle value and limit.
By their numbers in this assay, from the lowest: compound 2; then compounds 3 and 1 (each within the scatter of the next). At a limit, above all of these: compound 4.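

Putting 3-chloropropyl in place of (3-chloropropyl)amino on a carbonyl carbon takes away the nitrogen and its hydrogen-bond donor, and in this assay this gives an at least 3.5-fold higher number from compound 2 to compound 4 (0.55 log units; beyond the scatter), so this nitrogen cannot be removed without a measurable loss. Compound 4 gives > 100000 nM, which is a limit and not a number. Only the smallest possible size of the step is therefore known: the limit of > 100000 nM in this assay, at which 1 of the 4 values shown sits.

The compounds shown do not separate the nitrogen from its hydrogen, as an oxygen or a methylated nitrogen on the carbonyl carbon would. Nor do they show how a longer chain or an amine in place of the chlorine would behave.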